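A few compounds are considered here, and "the series" means these few. Any claim that something is new, unique, unknown or untested is made for them only; others in the source may bear on it.

The compounds share one core, and they differ only in the group attached to an amine nitrogen in a six-membered non-aromatic ring with two nitrogens. Compound 1 `Nc1nc(N)c2cc(CSC(=S)N3CCN(C4CCCCC4)CC3)ccc2n1` carries a cyclohexyl at that position. In a functional assay on HeLa cells (Homo sapiens) for antiproliferative activity, read by MTT assay, with a stated time of 72 h (a higher number here means a weaker inhibitor, a lower number a stronger inhibitor), compound 1 gives 5960 nM, the highest of the two numbers available, so among the measured compounds it is the weaker one. Compound 2 `Cc1ccc(N2CCN(C(=S)SCc3ccc4nc(N)nc(N)c4c3)CC2)cc1` carries a 4-methylphenyl on the same ring nitrogen, and in this assay compound 2 gives 2130 nM. The step of a 2.8-fold lower number from compound 1 to compound 2 (0.45 log units; beyond the scatter) is modest yet beyond the scatter. Compound 3 `Cc1ccccc1N1CCN(C(=S)SCc2ccc3nc(N)nc(N)c3c2)CC1`, which carries a 2-methylphenyl there, gives "not determined" (no result reported) in this assay, so no result is reported for it.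

Compound 4 `Nc1nc(N)c2cc(CSC(=S)N3CCN(c4ccc(F)cc4F)CC3)ccc2n1` is the next member of the set. Its change from compound 1 is 2,4-difluorophenyl in place of cyclohexyl on an amine nitrogen in a ring. Among the measured compounds shown here, the only measured step that speaks to this change is the one in which an aromatic six-membered ring replaced the cyclohexyl on that ring nitrogen, and there the change gave a 2.8-fold lower number from compound 1 to compound 2 (0.45 log units; beyond the scatter). Because the step of a 2.8-fold lower number from compound 1 to compound 2 (0.45 log units; beyond the scatter) came from the same kind of exchange, a lowering of comparable size is expected, and compound 4 is expected to show a 2.4-fold lower number from compound 1 to compound 4 (0.38 log units; beyond the scatter). Compound 4 is therefore estimated at 2500 nM, within a range from 1000 nM to 7000 nM.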

Compound 4, half-maximal inhibitory concentration: 3800 nM
Compound 4: the middle estimate sits 1.5-fold (0.18 log units) below what was measured; the measured number falls inside the stated range.
By their numbers in this assay, from the lowest: compounds 2, 4 and 1 (each within the scatter of the next, the first and the last beyond it).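

In this assay, replacing cyclohexyl with 2,4-difluorophenyl gives a 1.6-fold lower number from compound 1 to compound 4 (0.20 log units; within the scatter), while replacing 4-methylphenyl with 2,4-difluorophenyl gives a 1.8-fold higher number from compound 2 to compound 4 (0.25 log units; within the scatter), so the new compound cannot be separated from either of its two neighbours. This shows that a six-membered aromatic ring on this ring nitrogen does not always give a step beyond the scatter: the earlier exchange gave a 2.8-fold lower number from compound 1 to compound 2 (0.45 log units; beyond the scatter), but compound 4 goes against that single result, and the group on the aromatic ring may therefore matter at this position, although these numbers do not establish it. No measurement bears on why the two aromatic groups give steps of different standing from cyclohexyl.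

The compounds shown leave open whether an unsubstituted phenyl, a benzyl group or a phenyl carrying a methoxy group would stand nearer compound 2 or compound 1. Among the compounds shown here, they also leave open whether an amine or a carboxylic acid on the aromatic ring would move the number beyond the scatter, and with only three numbers, the range of this position remains only thinly mapped.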